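From a pyrrolidinone to a pyrazole amide: an expected solubility step

The compounds below may be only part of what the source reports. "The series", "measured", "known", "first", "only" and "open" are said of these compounds alone.

In a physicochemical assay for solubility, read by LC-MS, in phosphate buffer, with a stated time of 24 h, at pH 7.4 (a higher number here means a more soluble compound, a lower number a less soluble compound), compound 1 `Cc1nccn1-c1cnc(NCc2c(F)ccc3c2CCO3)c2cn[nH]c(=O)c12` gives 7000 nM and compound 2 `Cc1nc(CO)ccc1-c1cnc(NCc2c(F)ccc3c2CCO3)c2cn[nH]c(=O)c12` gives 3000 nM. Compound 3 `O=C1CCCN1c1cnc(NCc2c(F)ccc3c2CCO3)c2cn[nH]c(=O)c12` stands at < 2000 nM, which is a limit and not a number. Compound 4 `CN(C)C(=O)c1cc(-c2cnc(NCc3c(F)ccc4c3CCO4)c3cn[nH]c(=O)c23)n(C)n1` keeps the shared core but has 3-(dimethylcarbamoyl)-1-methyl-1H-pyrazol-5-yl in place of 2-oxopyrrolidin-1-yl on an aromatic carbon. Three measured exchanges on an aromatic carbon bear on this: a 2.3-fold lower number from compound 1 to compound 2 (0.37 log units; beyond the scatter) and an at least 3.5-fold lower number from compound 1 to compound 3 (0.54 log units; beyond the scatter) are modest, and an at least 1.5-fold lower number from compound 2 to compound 3 (0.17 log units; that floor lies within the scatter) has a floor within the scatter. Only a modest upward step is therefore expected, since an aromatic ring also enters in compound 2 at 3000 nM. The expected step is an at least 1.2-fold higher number from compound 3 to compound 4 (0.09 log units; that floor lies within the scatter). For compound 4, the estimated value is 2500 nM, with an expected range from 1000 nM to 7000 nM.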

Compound 4, solubility: 3000 nM
Estimate against measurement, compound 4: 1.2-fold (0.08 log units) below, and the stated range covers the measured number.
By their numbers in this assay, from the lowest: compounds 2 and 4 (each within the scatter of the next); then compound 1. At a limit, below all of these: compound 3.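

In this assay, the step to the new group reads no change at the digits printed from compound 2 to compound 4 (within the scatter), so this position gives two quite different aromatic groups, 6-(hydroxymethyl)-2-methylpyridin-3-yl and 3-(dimethylcarbamoyl)-1-methyl-1H-pyrazol-5-yl, the same printed number. The 2-methyl-1H-imidazol-1-yl group of compound 1 remains ahead of both, with a 2.3-fold lower number from compound 1 to compound 4 (0.37 log units; beyond the scatter). Against the 2-oxopyrrolidin-1-yl group the reading is an at least 1.5-fold higher number from compound 3 to compound 4 (0.17 log units; that floor lies within the scatter), and compound 3 has only a limit, so the true size of that step stays unknown: the limit of < 2000 nM in this assay, at which 1 of the 4 values shown sits.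

On these data alone, what stays open is whether the pyrazole ring or its dimethylcarbamoyl group sets the number for compound 4. Also open, as far as these compounds go, is how an amine or a carboxylic acid in place of that dimethylcarbamoyl group would read.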